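Swapping Azido for Amino on a Fluorinated Core

This account rests on a few compounds, and the source may have more. Where it says the series, first, only, none or still open, it means among the compounds named here.

Among the compounds with values here, in a functional assay on MDA-MB-468 cells (Homo sapiens) for antiproliferative activity, read by WST assay, with a stated time of 3 days (a higher number here means a weaker inhibitor, a lower number a stronger inhibitor), compound 2 `[N-]=[N+]=Nc1c(F)c(=O)[nH]c(=O)n1[C@@H]1O[C@H](CO)[C@@H](O)[C@H]1O` gives 1800 nM, the only actual number so far. Compound 3 `Nc1c(F)c(=O)[nH]c(=O)n1[C@@H]1O[C@H](CO)[C@@H](O)[C@H]1O` has amino in place of azido on an aromatic carbon, and it keeps the fluoro group. Compound 1 `Nc1cc(=O)[nH]c(=O)n1[C@@H]1O[C@H](CO)[C@@H](O)[C@H]1O` also carries amino but lacks the fluoro group, and it gives > 50000 nM, which is a limit of the assay, so a weakening is expected with amino in compound 3. The expected change is an 11-fold higher number from compound 2 to compound 3 (1.05 log units; beyond the scatter), which would lie beyond the usual scatter. For compound 3, the estimate is 20000 nM, within an expected range of 4000 nM to 50000 nM.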

Compound 3, half-maximal inhibitory concentration: 2600 nM
Beside the measured number, compound 3's estimate is 7.7-fold (0.89 log units) above it; measured number outside the range, below it.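

With the fluoro group kept, amino in place of azido on this aromatic carbon makes no clear difference in this assay (a 1.4-fold higher number from compound 2 to compound 3 (0.16 log units; within the scatter)). With amino in both compounds, fluoro in place of hydrogen is the change that counts (an at least 19-fold lower number from compound 1 to compound 3 (1.28 log units; beyond the scatter)). The value of compound 1 is a limit of the assay, not a number: (the limit of > 50000 nM in this assay, at which 1 of the 3 values shown sits).

Still open, as far as these compounds go, is how a chloro or a methyl group would read in place of the fluoro group. Also open, from the compounds shown here alone, is whether a longer amine, such as dimethylamino, would read like amino and azido.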